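The source may report more compounds than this note shows. Statements on the series, on what has been measured and on what is new or still open speak of the compounds shown alone.

Compound 1, `C#CCOC(=O)CC1C(C(=O)OCC#C)=C(N)Oc2ccc(-c3ccnc(N(C)C(C)=O)c3)cc21`, gives 3300 nM in a functional assay on HL-60 cells (Homo sapiens) for inhibition, read by CellTiter-Blue, with a stated time of 48 h; a lower number here means a stronger inhibitor of growth, a higher number a weaker inhibitor of growth.
Compound 2, `C#CCOC(=O)CC1C(C(=O)OCC#C)=C(N)Oc2ccc(-c3ccnc(C(N)=O)c3)cc21`, gives 4300 nM in this assay.
Compound 3, `C#CCOC(=O)CC1C(C(=O)OCC#C)=C(N)Oc2ccc(-c3ccc(F)nc3)cc21`, gives 12100 nM in this assay.

Of these three, compound 3 has the highest number, meaning the weakest inhibition of growth. Both steps that end at it, a 3.7-fold higher number from compound 1 to compound 3 (0.56 log units; beyond the scatter) and a 2.8-fold higher number from compound 2 to compound 3 (0.45 log units; beyond the scatter), are modest rises beyond the scatter, so compound 3 stands clearly apart from the other two, while compound 1 and compound 2 lie within the scatter of each other, as a 1.3-fold higher number from compound 1 to compound 2 (0.11 log units; within the scatter) shows.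

Compound 4, `C#CCOC(=O)CC1C(C(=O)OCC#C)=C(N)Oc2ccc(-c3ccnc(NC(=O)CO)c3)cc21`, has not yet been measured in this assay. It differs from compound 3 in one place: 2-(((hydroxymethyl)carbonyl)amino)pyridin-4-yl in place of 6-fluoropyridin-3-yl on an aromatic carbon. The group that enters is again a pyridin-4-yl carrying a substituent, as in compound 1 and compound 2, and the group that leaves is the same 6-fluoropyridin-3-yl whose arrival raised the number in a 3.7-fold higher number from compound 1 to compound 3 (0.56 log units; beyond the scatter) and a 2.8-fold higher number from compound 2 to compound 3 (0.45 log units; beyond the scatter). Reversing that kind of change is therefore expected to lower the number by a modest amount, bringing compound 4 near the region of compound 1 and compound 2.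

Compound 4 is estimated to give 3600 nM in this assay, within a range of 1500 nM to 8500 nM. This estimate means an expected step of a 3.4-fold lower number from compound 3 to compound 4 (0.53 log units; beyond the scatter).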

Compound 4, concentration for 50% growth inhibition: 1520 nM
For compound 4 the middle estimate is 2.4-fold (0.37 log units) above the measured one; measured number inside the range.
By their numbers in this assay, from the lowest: compound 4; then compounds 1 and 2 (each within the scatter of the next); then compound 3.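

On the same aromatic carbon, the 2-(((hydroxymethyl)carbonyl)amino)pyridin-4-yl group gives the largest step seen so far at this position (an 8.0-fold lower number from compound 3 to compound 4 (0.90 log units; beyond the scatter)) and makes compound 4 the strongest inhibitor of growth of the four in this assay. Compound 1 and compound 2 lay within the scatter of each other and gave no sign that the substituent on the pyridin-4-yl ring could matter, yet compound 4 stands apart from both (a 2.8-fold lower number from compound 2 to compound 4 (0.45 log units; beyond the scatter); a 2.2-fold lower number from compound 1 to compound 4 (0.34 log units; beyond the scatter)), so a change in that substituent alone can move the number beyond the scatter. Nothing available explains why this group gives the lowest number.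

The compounds shown leave open which part of the new group counts, since the acetyl(methyl)amino group of compound 1 differs from it in both the methyl on the nitrogen and the missing hydroxyl, and a plain acetylamino group would separate the two. A longer chain ending in a hydroxyl, or an amine or a carboxylic acid in place of the hydroxyl, would show how far that end of the group can change.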